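Alkyne cap variation on a rigid nucleoside series

A few compounds are considered here, and "the series" means these few. Any claim that something is new, unique, unknown or untested is made for them only; others in the source may bear on it.

Measured in an assay on CHO cells for displacement of a labelled ligand from adenosine receptor A1 (Homo sapiens), read by scintillation counting, with a stated time of 60 min, tested at 10 uM; on this read-out lower numbers stand for less inhibition and higher numbers for more inhibition at the one concentration tested (going by the name of the read-out):
compound 1 `CNC(=O)[C@@]12C[C@@H]1[C@@H](n1cnc3c(NC)nc(C#Cc4ccc(-c5ccccc5)cc4)nc31)[C@H](O)[C@@H]2O`: 18%
compound 2 `CNC(=O)[C@@]12C[C@@H]1[C@@H](n1cnc3c(NC)nc(C#Cc4ccc(CO)cc4)nc31)[C@H](O)[C@@H]2O`: 16%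
compound 3 `CNC(=O)[C@@]12C[C@@H]1[C@@H](n1cnc3c(NC)nc(C#Cc4cc5ccccc5o4)nc31)[C@H](O)[C@@H]2O`: 13%

Compound 3 stands with the other two; the steps of a number 5 percentage points lower from compound 1 to compound 3 (within the scatter) and a number 3 percentage points lower from compound 2 to compound 3 (within the scatter) are within the scatter, as is a number 2 percentage points lower from compound 1 to compound 2 (within the scatter), so the three numbers are indistinguishable.

Compound 4 `CNC(=O)[C@@]12C[C@@H]1[C@@H](n1cnc3c(NC)nc(C#CC4CC4)nc31)[C@H](O)[C@@H]2O` differs from compound 3 by cyclopropyl in place of 1-benzofuran-2-yl on a triple-bonded carbon. Among the measured compounds shown here, two measured steps touch the same triple-bonded carbon, a number 5 percentage points lower from compound 1 to compound 3 (within the scatter) and a number 3 percentage points lower from compound 2 to compound 3 (within the scatter), and both were within the scatter; however, each of those swaps one aromatic group for another, whereas compound 4 brings in cyclopropyl, a non-aromatic three-membered ring. For the measured compounds named here, no measured step bears directly on such a change, so the expectation rests only on the flat picture across compounds 1 to 3. For compound 4 the expected step is a number 1 percentage points lower from compound 3 to compound 4 (within the scatter), that is, none beyond the scatter, with wide uncertainty. Compound 4 is therefore estimated at 12% in this assay, within 0% to 30%.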

Compound 4, a percentage reported as inhibition, at one concentration (the size of the read-out at that concentration, not a potency): 38%
Compound 4: the middle estimate sits 26 percentage points below what was measured; measured number above the stated range.
By their numbers in this assay, from the lowest: compounds 3, 2 and 1 (each within the scatter of the next); then compound 4.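

On the triple-bonded carbon, the identity of the cap does register in this assay: cyclopropyl gives a number 25 percentage points higher from compound 3 to compound 4 (beyond the scatter) and a number 22 percentage points higher from compound 2 to compound 4 (beyond the scatter) and a number 20 percentage points higher from compound 1 to compound 4 (beyond the scatter) in place of the three aromatic caps. The flat picture across compounds 1 to 3 therefore held only among aromatic caps, and it does not extend to compound 4, whose cap is a three-membered non-aromatic ring of 3 heavy atoms rather than the 9 of 1-benzofuran-2-yl. Nothing measured here accounts for the rise.

With a single non-aromatic cap, the rise cannot be assigned to the loss of aromaticity, to the smaller cap or to the three-membered ring itself. Caps such as cyclohexyl, a short open chain like n-propyl or a primary amine on a short chain would help separate these readings.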